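The compounds below may be only part of what the source reports. "The series", "measured", "known", "first", "only" and "open" are said of these compounds alone.

The shared core is that of compound 1 `COc1ccc(-c2nc3cc(/C=C4\SC(=O)NC4=O)ccc3[nH]2)cc1OC`, which in an ADME assay on HEK-293T cells (Homo sapiens) for inhibition, read by MTT assay, with a stated time of 48 h (on this read-out higher numbers stand for weaker inhibition and lower numbers for stronger inhibition), gives 21700 nM. Compound 2 `COc1cc(-c2nc3cc(/C=C4\SC(=O)N(CC(=O)N5CCCCC5)C4=O)ccc3[nH]2)cc(OC)c1OC` gives 21500 nM in this assay, a value that lies within the scatter of that of compound 1. Compound 3 `COc1cc(OC)c(-c2nc3cc(/C=C4\SC(=O)N(CC(=O)N5CCCCC5)C4=O)ccc3[nH]2)cc1OC` reaches only the limit of this assay, > 50000 nM, so for compound 3 no number is known. Going by the values given here, the single measured step, an at least 2.3-fold higher number from compound 2 to compound 3 (0.36 log units; beyond the scatter), concerns a different part of the molecule, and the limit of > 50000 nM in this assay, at which 1 of the 3 values shown sits, is that of compound 3 alone. Compound 4 `COc1cc(OC)c(-c2nc3cc(/C=C4\SC(=O)N(Cc5cccc(C)c5)C4=O)ccc3[nH]2)cc1OC` carries 3-methylphenyl in place of (piperidin-1-yl)carbonyl on a saturated chain carbon bound to an amide-type nitrogen in a ring. Among the compounds with values here, no measured step bears on this change, so no step beyond the scatter is expected in this assay, a number no higher from compound 3 to compound 4 (the limit leaves the size open). Compound 4 is therefore estimated at 50000 nM, between 20000 nM and 150000 nM.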

Compound 4, half-maximal inhibitory concentration: 3350 nM
For compound 4 the middle estimate is 15-fold (1.17 log units) above the measured one; measured number below the stated range.
By their numbers in this assay, from the lowest: compound 4; then compounds 2 and 1 (each within the scatter of the next). At a limit, above all of these: compound 3.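

In this assay, 3-methylphenyl in place of (piperidin-1-yl)carbonyl on a saturated chain carbon bound to an amide-type nitrogen in a ring gives an at least 14-fold lower number from compound 3 to compound 4 (1.17 log units; beyond the scatter). This shows that this place, which the earlier step did not touch, can shift the number strongly downward. The full size of the step stays open because compound 3 stands at a limit: the limit of > 50000 nM in this assay, at which 1 of the 4 values shown sits.

As far as these compounds go, whether a plain benzyl or a longer chain ending in an amine would act like 3-methylbenzyl remains open. So does whether 3-methylbenzyl acts alike with 3,4,5-trimethoxyphenyl on the shared core.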